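Removing One Methyl from a Weak Growth Inhibitor

The compounds below may be only part of what the source reports. "The series", "measured", "known", "first", "only" and "open" are said of these compounds alone.

Compound 1 `Cc1ccnc2nc(-c3cccc4ccccc34)cc(O)c12`: 12 nM
Compound 2 `Cc1cc(C)c2c(O)cc(-c3cccc4ccccc34)nc2n1`: 9550 nM

In a functional assay on CAKI-1 cells (Homo sapiens) for antiproliferative activity (a higher number here means a weaker inhibitor of growth, a lower number a stronger inhibitor of growth), compound 2 gives the higher of the two numbers, 9550 nM. Compound 3 `Cc1ccc2c(O)cc(-c3cccc4ccccc34)nc2n1` loses one of the two methyl groups of compound 2: hydrogen in place of methyl on an aromatic carbon. Within the data shown here, one measured step bears on this, an 800-fold higher number from compound 1 to compound 2 (2.90 log units; beyond the scatter), a large change on adding a methyl. The methyl leaving now is not that one. It is the methyl opposite the ring nitrogen, which compound 1 also carries, so compound 3 keeps the methyl added in that step. Removing this other methyl has not been measured on its own, so only a partial recovery is expected, smaller than the measured step and towards a lower number. The expected change is a 24-fold lower number from compound 2 to compound 3 (1.38 log units; beyond the scatter). Compound 3 is estimated at 400 nM, with a range of 30 nM to 5000 nM.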

Compound 3, concentration for 50% growth inhibition: 6030 nM
Compound 3: the middle estimate sits 15-fold (1.18 log units) below what was measured; measured number outside the range, above it.
By their numbers in this assay, from the lowest: compound 1; then compounds 3 and 2 (each within the scatter of the next).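

On this aromatic carbon, opposite the ring nitrogen, hydrogen in place of methyl gives a 1.6-fold lower number from compound 2 to compound 3 (0.20 log units; within the scatter) in this assay, so taking this methyl away leaves the number within the usual scatter. This small step contrasts with the large one seen on adding the other methyl, an 800-fold higher number from compound 1 to compound 2 (2.90 log units; beyond the scatter), and compound 3 still carries that other methyl. No available evidence explains why the two methyl changes differ so much in size.

From the compounds shown here alone, it remains open whether this carbon would tolerate other groups equally well, such as an ethyl, a methoxy or an amine. Also open, going by these compounds, is how the shared core would behave with hydrogen on both carbons that carry a methyl in compound 2.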